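This account rests on a few compounds, and the source may have more. Where it says the series, first, only, none or still open, it means among the compounds named here.

Compound 1 `Nc1ccccc1NC(=O)c1ccc(CSC(=S)N2CCN(Cc3ccccn3)CC2)cc1`, compound 2 `Nc1ccccc1NC(=O)c1ccc(CSC(=S)N2CCN(Cc3ccncc3)CC2)cc1` and compound 3 `Nc1ccccc1NC(=O)c1ccc(CSC(=S)N2CCN(C(c3ccccc3)c3ccccc3)CC2)cc1` share one core and differ only in the group attached to the saturated chain carbon bound to an amine nitrogen in a ring. In a functional assay on HeLa cells (Homo sapiens) for antiproliferative activity, read by CCK-8 assay, with a stated time of 72 h, tested at 2 uM (on this read-out lower numbers stand for a weaker effect and higher numbers for a stronger effect at the one concentration tested), compound 1 gives 14.2%, compound 2 gives 59.5%, and compound 3 gives 8%, the lowest of the three numbers; compound 1 lies within the scatter of it, while compound 2 lies beyond. Among the compounds with values here, the only measured step, a number 45.3 percentage points higher from compound 1 to compound 2 (beyond the scatter), swaps one ring for another and so does not address the change at hand. Compound 4 `Nc1ccccc1NC(=O)c1ccc(CSC(=S)N2CCN(Cc3ccccc3)CC2)cc1` arises from compound 3 by hydrogen in place of phenyl on a saturated chain carbon bound to an amine nitrogen in a ring and an aromatic carbon. Within the data shown here, with no measured step bearing on this change, its direction remains open. Compound 4 is estimated at 20%, within 5% to 50%, an expected a number 12 percentage points higher from compound 3 to compound 4 (beyond the scatter).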

Compound 4, a percentage reported as inhibition, at one concentration (the size of the read-out at that concentration, not a potency): 20.6%
Estimate against measurement, compound 4: 0.6 percentage points below; low and high end bracket the measured number.
By their numbers in this assay, from the lowest: compounds 3, 1 and 4 (each within the scatter of the next, the first and the last beyond it); then compound 2.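

In this assay the change at this carbon can now be read directly: hydrogen in place of phenyl gives a number 12.6 percentage points higher from compound 3 to compound 4 (beyond the scatter), so this carbon does not need a second phenyl for the effect seen here. Against the plain phenyl of compound 4, the two pyridine compounds part ways, with a number 38.9 percentage points lower from compound 2 to compound 4 (beyond the scatter) but a number 6.4 percentage points higher from compound 1 to compound 4 (within the scatter), so only pyridin-4-yl stands apart. Nothing available explains these differences. Still open, from the compounds shown here alone, is how pyridin-3-yl, or a phenyl carrying a methoxy group, would read on this carbon. Going by these compounds, with one concentration tested, potency also remains open.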